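The source may report more compounds than this note shows. Statements on the series, on what has been measured and on what is new or still open speak of the compounds shown alone.

Measured so far:
Compound 1, `C#CCNCCN(C)CCNc1ccnc2cc(Cl)ccc12`: 105000 nM
Compound 2, `CN(CCNCc1cn(-c2ccccc2Cl)nn1)CCNc1ccnc2cc(Cl)ccc12`: 12000 nM

Both compounds were tested in a functional assay on HCC827 cells (Homo sapiens) for antiproliferative activity, read by sulforhodamine B assay, with a stated time of 72 h; a higher number here means a weaker inhibitor, a lower number a stronger inhibitor. Compound 1 gives 105000 nM, while compound 2 gives 12000 nM. Of the two numbers, compound 2 has the lower one; the number for compound 1 stands higher by a margin beyond the scatter of repeated measurements, so among these two compounds compound 2 is the stronger inhibitor.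

Compound 3, `CN(CCNCc1cn(-c2nc3ccccc3[nH]2)nn1)CCNc1ccnc2cc(Cl)ccc12`, has not yet been measured in this assay. It differs from compound 2 in one place: 1H-benzimidazol-2-yl in place of 2-chlorophenyl on an aromatic nitrogen. The group that enters carries a hydrogen-bond donor and a hydrogen-bond acceptor, which the 2-chlorophenyl that leaves did not. Among the measured compounds shown here, no pair of measured compounds shows what this kind of change does in this assay, so the size of the step is open. The step is expected to be small, a 1.5-fold lower number from compound 2 to compound 3 (0.18 log units; within the scatter), towards a slightly lower number but not clearly beyond the scatter. Compound 3 is accordingly estimated at 8000 nM, with a range from 2500 nM to 25000 nM.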

Compound 3, half-maximal inhibitory concentration: 32000 nM
Beside the measured number, compound 3's estimate is 4.0-fold (0.60 log units) below it; measured number outside the range, above it.
By their numbers in this assay, from the lowest: compound 2; then compound 3; then compound 1.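

Here, for the first time, a change is measured on an aromatic nitrogen of the five-membered aromatic ring with 3 nitrogen, and this assay responds to it: 1H-benzimidazol-2-yl in place of 2-chlorophenyl gives a 2.7-fold higher number from compound 2 to compound 3 (0.43 log units; beyond the scatter). The entering group has more heavy atoms than the one that leaves, and it adds a hydrogen-bond donor and a hydrogen-bond acceptor, yet these additions come with a weaker, not a stronger, inhibitor in this single comparison. Nothing available explains why the number rises with this change.

This one step alters the ring system, the chlorine and the hydrogen-bond count together, so the compounds shown do not tell which of these differences goes with the higher number. Unsubstituted phenyl at this position would show what the chlorine contributes, while 1-methyl-1H-benzimidazol-2-yl, with a methyl group in place of the ring hydrogen on nitrogen, would keep both rings of the entering group but not its hydrogen-bond donor.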